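Reversed sulfonamide on the benzamide ring: compound 4

The compounds below may be only part of what the source reports. "The series", "measured", "known", "first", "only" and "open" are said of these compounds alone.

Among the measured compounds shown here, compound 3 `CCOc1ccc(C(C)=O)cc1NC(=O)c1cccc(S(=O)(=O)Nc2ccccc2)c1` stands lowest of the three numbers so far: in an assay on isolated protein for binding affinity to histone acetyltransferase p300 (Homo sapiens), read by thermal shift assay, tested at 100 uM (a higher number here means that the compound stabilises the target more against heat, a lower number that the compound stabilises the target less), compound 3 gives 0 degrees C. Compound 2 `CC(=O)c1ccc(OCC(C)C)c(NC(=O)c2cccc(C(=O)O)c2)c1` is nearest to it and in this assay compound 2 gives 3 degrees C, beyond the scatter above compound 3. Compound 1 `CCCOc1ccc(C(C)=O)cc1NC(=O)c1cccc(C(=O)O)c1` is furthest, and in this assay compound 1 gives 3.4 degrees C, likewise beyond the scatter. For the measured compounds named here, the one step between measured compounds that differ in a single place, a number 0.40 degrees C lower from compound 1 to compound 2 (within the scatter), concerns a methyl in place of a hydrogen on a saturated chain carbon and lies within the scatter; it touches another part of the molecule and does not bear on the change considered here.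

Compound 4 `CCOc1ccc(C(C)=O)cc1NC(=O)c1cccc(NS(=O)(=O)c2ccccc2)c1` keeps every atom of compound 3 but joins them differently: (phenylsulfonyl)amino in place of phenylsulfamoyl on an aromatic carbon. Going by the values given here, no measured pair in this set shows what such a reversal does in this assay; compounds 1 and 2 carry a carboxylic acid rather than a phenylsulfamoyl group, so their numbers give no guide for the swapped sulfonamide. The expectation therefore rests on compound 3 alone. The estimated step of a number 0.50 degrees C higher from compound 3 to compound 4 (within the scatter) is none beyond the scatter, with a wide range to either side. Compound 4 is expected to give 0.5 degrees C, between -1.5 degrees C and 3 degrees C.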

Compound 4, shift of the target's melting temperature: 0.4 degrees C
The estimate for compound 4 lay 0.10 degrees C above the measured number; measured number inside the range.
By their numbers in this assay, from the lowest: compounds 3 and 4 (each within the scatter of the next); then compounds 2 and 1 (each within the scatter of the next).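

In this assay, turning the sulfonamide around on this aromatic carbon gives a number 0.40 degrees C higher from compound 3 to compound 4 (within the scatter), so (phenylsulfonyl)amino and phenylsulfamoyl cannot be told apart at this position. Among the compounds shown here, this is the first reading of a change at this position between two sulfonamides, which compounds 1 and 2, with their carboxylic acid, could not give. The two groups match in every count of atoms, double bonds, hydrogen-bond donors and hydrogen-bond acceptors, and no measurement of a property of either group accompanies this pair.

Still open, on these data alone, is how the sulfonamide pair relates to compound 1 and compound 2: a carboxylic acid on this same aromatic carbon, with the ethoxy chain of compound 3 and compound 4 kept, would provide a single-place comparison with each sulfonamide and with compound 1. Also open, as far as these compounds go, is whether the phenyl ring on the sulfonamide matters in this position, which a methyl on the sulfonyl group or an unsubstituted sulfamoyl group in its place could address.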